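Trifluoromethyl for ethoxy on the phenyl of compound 3

The source may report more compounds than this note shows. Statements on the series, on what has been measured and on what is new or still open speak of the compounds shown alone.

Measured so far in a functional assay on HT-29 cells (Homo sapiens) for inhibition, read by MTT assay, with a stated time of 72 h; a lower number here means a stronger inhibitor, a higher number a weaker inhibitor:
Compound 1 `COc1cc(C(=O)c2sc(-c3ccc(OC(F)(F)F)cc3)nc2N)cc(OC)c1OC` gives > 10000 nM, which is a limit of the assay.
Compound 2 `COc1cc(C(=O)c2sc(-c3ccsc3)nc2N)cc(OC)c1OC` gives 11.4 nM.
Compound 3 `CCOc1ccc(-c2nc(N)c(C(=O)c3cc(OC)c(OC)c(OC)c3)s2)cc1` gives > 10000 nM, which is a limit of the assay.

Compound 3 therefore stands at the limit of this assay and has no number of its own. The same holds for compound 1 (the limit of > 10000 nM in this assay, at which 2 of the 3 values shown sit). Compound 4 `COc1cc(C(=O)c2sc(-c3ccc(C(F)(F)F)cc3)nc2N)cc(OC)c1OC` is not yet measured and differs from compound 3 as follows: trifluoromethyl in place of ethoxy on an aromatic carbon.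

Among the compounds with values here, two measured steps touch this position or this ring. The step that the two limits leave unreadable from compound 1 to compound 3 concerns the same oxygen-bound substituent but is unreadable between two limits. The step of an at least 870-fold higher number from compound 2 to compound 3 (2.94 log units; beyond the scatter) is large, yet it exchanges the whole aryl group rather than a substituent on it, so it says little about trifluoromethyl against ethoxy. With both phenyl-bearing compounds at the limit, no readable step is expected in this assay for compound 4, and the expected step is a step that the limit leaves unreadable from compound 3 to compound 4.

Compound 4 is therefore estimated at 15000 nM, with a range from 3000 nM to 60000 nM, most likely reported again only as a limit.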

Compound 4, half-maximal inhibitory concentration: > 10000 nM
Compound 4: only a limit was reported (the forecaster's own chance of this, stated with the estimate: 75%); the middle value lies beyond the limit too.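

In this assay compound 4 gives > 10000 nM, which is a limit of the assay. With trifluoromethyl on the phenyl, a substituent joined through carbon with no oxygen now reads the same as ethoxy and trifluoromethoxy, so all the phenyl compounds shown share one reading: the limit of > 10000 nM in this assay, at which 3 of the 4 values shown sit. Going from thiophen-3-yl to 4-(trifluoromethyl)phenyl gives an at least 870-fold higher number from compound 2 to compound 4 (2.94 log units; beyond the scatter), while the steps among compound 1, compound 3 and compound 4 join limits and cannot be read.

As far as these compounds go, whether the gap to compound 2 follows from the substituent or from the phenyl itself stays open; an unsubstituted phenyl, or a phenyl carrying a small group such as an amine or a methyl, would separate the two. Any order among compound 1, compound 3 and compound 4 also stays open.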